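The Same Methoxy Change, Made Twice

This account rests on a few compounds, and the source may have more. Where it says the series, first, only, none or still open, it means among the compounds named here.

Three compounds have been measured in a functional assay on RPMI-8226 cells (Homo sapiens) for cytotoxicity, read by sulforhodamine B assay, with a stated time of 48 h, tested at 10 uM; a higher number here means a weaker effect of the compound at the concentration tested, a lower number a stronger effect:

Compound 1 `COc1cc(-c2cc(/C=C/C(=O)c3ccc(N)cc3)[nH]n2)cc(OC)c1OC` gives -35%
Compound 2 `COc1ccc(C(=O)/C=C/c2cc(-c3cc(OC)c(OC)c(OC)c3)n[nH]2)cc1OC` gives -50%
Compound 3 `COc1ccc(-c2cc(/C=C/C(=O)c3ccc(N)cc3)[nH]n2)cc1OC` gives -20%

Compound 1 differs from compound 3 by one change, (methoxy in place of hydrogen on an aromatic carbon), and this step gave a number 15 percentage points lower from compound 3 to compound 1 (beyond the scatter). Compound 2 differs from compound 1 by a change at the carbonyl side, and that step gave a number 15 percentage points lower from compound 1 to compound 2 (beyond the scatter), leaving compound 2 with the lowest number of the three. The difference between the cores of compound 2 and compound 3 is not broken down here.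

Compound 4 `COc1cc(C(=O)/C=C/c2cc(-c3cc(OC)c(OC)c(OC)c3)n[nH]2)cc(OC)c1OC` has not been measured. It differs from compound 2 by methoxy in place of hydrogen on an aromatic carbon, the same change that turned compound 3 into compound 1. Because a number 15 percentage points lower from compound 3 to compound 1 (beyond the scatter) the expected step is a similar one, a number 12 percentage points lower from compound 2 to compound 4 (beyond the scatter), with added uncertainty since the change now sits on the other part of the core. The estimate for compound 4 is -62%.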

Compound 4, a percentage reported as activity, at one concentration (the size of the read-out at that concentration, not a potency): -38%
The estimate for compound 4 lay 24 percentage points below the measured number, and the stated range ends below it.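

In this assay, methoxy in place of hydrogen on an aromatic carbon gave a number 12 percentage points higher from compound 2 to compound 4 (beyond the scatter). Set beside the earlier step, the same change moved the number in opposite directions on the two cores: the same change on two cores in this assay, a number 15 percentage points lower (beyond the scatter) from compound 3 to compound 1 and a number 12 percentage points higher (beyond the scatter) from compound 2 to compound 4, 27 percentage points apart, beyond the scatter of two such steps. For the compounds shown here, this shows that the result of this change cannot simply be carried from one core to another, but with only two pairs it does not show which difference between the cores sets the direction, or how other cores would respond.

The compounds shown leave open how a different group on that aromatic carbon, such as ethoxy or an amine, would compare with methoxy. They also leave open whether either of those groups would give steps that agree across the two cores.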